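From 2-hydroxyphenyl to 3,4,5-trimethoxyphenyl: an open step

The compounds below may be only part of what the source reports. "The series", "measured", "known", "first", "only" and "open" are said of these compounds alone.

Values in a functional assay on HL-60 cells (Homo sapiens) for antiproliferative activity, read by MTT assay; a higher number here means a weaker inhibitor, a lower number a stronger inhibitor
Compound 1 `O=C(N/N=C/c1ccccc1[N+](=O)[O-])c1cn(C2CC2)c2cc(N/N=C/c3ccccc3[N+](=O)[O-])c(F)cc2c1=O` gives <= 25000 nM
Compound 2 `O=C(N/N=C/c1ccccc1O)c1cn(C2CC2)c2cc(N3CCNCC3)c(F)cc2c1=O` gives <= 25000 nM

Compound 2 stands on a limit and not on a number (<= 25000 nM). Compound 1 also gives only a limit (<= 25000 nM). Both measured compounds therefore sit at the same reported bound (the limit of <= 25000 nM in this assay, at which 2 of the 2 values shown sit). Compound 3 `COc1cc(/C=N/NC(=O)c2cn(C3CC3)c3cc(N4CCNCC4)c(F)cc3c2=O)cc(OC)c1OC` carries 3,4,5-trimethoxyphenyl in place of 2-hydroxyphenyl on a carbon with a double bond to nitrogen. For the measured compounds named here, no measured step guides this change, so only a moderate move toward stronger inhibition in this assay is expected, and that with little confidence. The expected change is modest (a step that the limit leaves unreadable from compound 2 to compound 3). Compound 3 is estimated at 9000 nM (expected range 2000 nM to 30000 nM).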

Compound 3, half-maximal inhibitory concentration: <= 25000 nM
Compound 3: no number, only a limit; the forecaster's own chance of this, stated with the estimate: 35%; the middle value lies beyond the limit too.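

In this assay compound 3 gives only a limit, <= 25000 nM. Compound 2 also stands on a limit, and no step between compound 2 and compound 3 can be read: the limit of <= 25000 nM in this assay, at which 3 of the 3 values shown sit.

The compounds shown leave open how strongly each inhibits, and whether 3,4,5-trimethoxyphenyl in place of 2-hydroxyphenyl changes that at all.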